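The source may report more compounds than this note shows. Statements on the series, on what has been measured and on what is new or still open speak of the compounds shown alone.

Compound 1 `CN1CCCN(CCn2ccc3ccc(Br)cc32)CC1` — 93%
Compound 2 `Brc1ccc2ccn(CCN3CCC4CCCCN4CC3)c2c1` — 71%
Compound 3 `CN1CCCN(CCn2ccc3c(Br)cccc32)CC1` — 33%

Of the compounds shown here, three have been tested in an assay on HEK293 cells for binding affinity to 5-hydroxytryptamine receptor 7 (Homo sapiens), read by radioligand binding, tested at 1 uM; a lower number here means less inhibition, a higher number more inhibition at the concentration tested (going by the name of the read-out). Compound 1 gives the highest of the three readings, 93%. Compound 2 comes nearest, its number being lower by a gap beyond the usual scatter, and compound 3 lies furthest away, lower by a gap well beyond the scatter. Between compound 1 and compound 3 the bromo atom sits at a different place on the shared core, which is all that separates their two readings.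

Compound 4 `C#Cc1ccc2ccn(CCN3CCCN(C)CC3)c2c1` has not yet been measured. It differs from compound 1 in one place: ethynyl in place of bromo on an aromatic carbon. The bromo that leaves and the ethynyl that enters are both small groups without hydrogen-bond donors or acceptors and without charge, and they occupy the same aromatic carbon, meta to a fused ring and para to a fused ring.

Among the measured compounds shown here, no pair of measured compounds shows the effect of this kind of swap, so the expectation rests on compound 1 alone. A step of modest size, downward or none beyond the scatter, is expected in this assay, a number 13 percentage points lower from compound 1 to compound 4 (beyond the scatter). For compound 4 the estimated inhibition is 80%, within a range from 55% to 95%.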

Compound 4, a percentage reported as inhibition, at one concentration (the size of the read-out at that concentration, not a potency): 79%
Beside the measured number, compound 4's estimate is 1 percentage points above it; low and high end bracket the measured number.
By their numbers in this assay, from the lowest: compound 3; then compounds 2 and 4 (each within the scatter of the next); then compound 1.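

Placing ethynyl instead of bromo on this aromatic carbon, meta to a fused ring and para to a fused ring, gives in this assay a number 14 percentage points lower from compound 1 to compound 4 (beyond the scatter) and leaves compound 4 at 79% of inhibition at the concentration tested. The earlier compounds shown here showed only that moving the bromo around the shared core goes with a different reading, whereas this pair holds the place fixed and changes the group, so it shows that the reading at this carbon does not depend on having a bromine there, although the swap does cost a modest step beyond the usual scatter. Nothing measured here explains why this swap lowers the reading.

The compounds shown say nothing about how other groups on the same carbon would behave, such as a nitrile, a methoxy group, a primary amine or a longer chain such as propynyl, so it remains unknown how large a group this place accepts. On these data alone, it also remains open whether ethynyl would track bromo at the other place on the core, and a reading at one concentration does not give a potency for either compound.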